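A Hydroxy Group Enters the Core of Compound 2

The source may hold more compounds than are shown below. What is called first, only, known or untested is meant among the compounds shown, and "the series" means these compounds.

Compound 1 `C/C1=C/[C@]23O[C@H]2[C@H](C)C=C3C(=O)[C@@](C)(O)C(=O)CC(C)(C)/C=C/C1=O` and compound 2 `CC1=C2CC(C)(C)/C=C/C/C(C)=C\C3=C[C@H](C)C[C@]3(O2)C1=O` share a core and were both tested in an ADME assay on Raji cells (Homo sapiens) for cytotoxicity, read by CellTiter-Glo, with a stated time of 72 h; on this read-out higher numbers stand for an effect only at larger amounts of compound and lower numbers for an effect already at smaller amounts. Compound 1 gives 26000 nM there, and compound 2 gives 26000 nM, level with compound 1 within the scatter. Compound 3 `CC1=C2CC(C)(C)/C=C/[C@H](O)/C(C)=C\C3=C[C@H](C)C[C@]3(O2)C1=O` is not yet measured; it differs from compound 2 by hydroxy in place of hydrogen on a saturated ring carbon. For the measured compounds named here, no measured pair shows what such a change does here, so the expected step of no change at the digits printed from compound 2 to compound 3 (within the scatter) is none beyond the scatter, in either direction. Compound 3 is therefore estimated at 26000 nM in this assay, with a range from 10000 nM to 65000 nM.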

Compound 3, half-maximal effective concentration: 26000 nM
For compound 3 middle estimate and measured number coincide at the digits printed; the measured number falls inside the stated range.
By their numbers in this assay, from the lowest: compounds 1, 2 and 3 (each within the scatter of the next).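

Hydroxy in place of hydrogen on this saturated ring carbon, next to the ring atom that bears a methyl group, gives no change at the digits printed from compound 2 to compound 3 (within the scatter) in this assay. For the compounds shown here, this is the first measured pair for this position, and it shows that the carbon can carry hydroxy with no step beyond the scatter on this read-out. As far as these compounds go, what an amine, a methoxy group or a carboxylic acid would do on the same carbon remains open, as does the effect of hydroxy on other carbons of the shared core. Nothing shown gives a reason for this result.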